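Replacing a methoxy-bearing side chain with phenyl

This account rests on a few compounds, and the source may have more. Where it says the series, first, only, none or still open, it means among the compounds named here.

Measured compounds:
compound 1 `COC(C)(C)[C@@H](O)C(=O)N1[C@H](C(=O)NCc2cc(Cl)ccc2-n2cnnn2)C[C@@H]2C[C@@H]21`: 40 mL.min-1.g-1
compound 2 `CC(C)(C)[C@@H](O)C(=O)N1C[S+]([O-])C[C@H]1C(=O)NCc1cc(Cl)ccc1-n1cnnn1`: < 12 mL.min-1.g-1
compound 3 `CCCC[C@@H](O)C(=O)N1C[C@H]2C[C@H]2[C@H]1C(=O)NCc1cc(Cl)ccc1-n1cnnn1`: 32 mL.min-1.g-1

Of the compounds shown here, three sharing the same amide core have been measured in an ADME assay on liver for metabolic stability, with Liver microsome (Homo sapiens) as the target, read by LC-MS, using microsomes; a higher number here means faster removal of the compound, a lower number slower removal. Compound 1 gives 40 mL.min-1.g-1. Compound 3 gives 32 mL.min-1.g-1, and the two numbers lie within the usual scatter of each other, so no order between them can be claimed. For compound 2 the assay reports only a limit, < 12 mL.min-1.g-1, not a number. the limit of < 12 mL.min-1.g-1 in this assay, at which 1 of the 3 values shown sits.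

Compound 4 `O=C(NCc1cc(Cl)ccc1-n1cnnn1)[C@@H]1C[C@@H]2C[C@@H]2N1C(=O)[C@H](O)c1ccccc1` has not yet been measured. It differs from compound 1 in one place: phenyl in place of 1-methoxy-1-methylethyl on a saturated chain carbon bound to a carbonyl carbon and an oxygen on a saturated carbon. Among the compounds with values here, no measured pair shows this change, so its effect is open. Compound 4 is expected to sit near compound 1, with the step of a 1.1-fold higher number from compound 1 to compound 4 (0.05 log units; within the scatter) not expected to go beyond the scatter; its estimated value is 45 mL.min-1.g-1, between 20 mL.min-1.g-1 and 100 mL.min-1.g-1.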

Compound 4, intrinsic clearance in microsomes: < 16 mL.min-1.g-1
Compound 4 ended at the assay's limit; the forecaster's own chance of this, stated with the estimate: 10%; at least 2.8-fold (0.44 log units) between middle value and limit.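

Within the data shown here, the earlier compounds differ from one another in more than one place, so this pair is the first to isolate the side chain on a saturated chain carbon bound to a carbonyl carbon and an oxygen on a saturated carbon. There, phenyl in place of 1-methoxy-1-methylethyl gives an at least 2.5-fold lower number from compound 1 to compound 4 (0.39 log units; beyond the scatter) in this assay. For compound 4 the read-out is a limit and not a number, so the full size of the step stays unknown: the limit of < 16 mL.min-1.g-1 in this assay, at which 1 of the 4 values shown sits.

Whether the phenyl ring itself or the loss of the methoxy group accounts for the step remains open. So does whether cyclohexyl or pyridyl at this place would read like phenyl.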